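This account rests on a few compounds, and the source may have more. Where it says the series, first, only, none or still open, it means among the compounds named here.

Measured so far:
compound 1 `O=C(CCSc1nc2ccccc2c(=O)[nH]1)N[C@H]1CC[C@H](c2nnc(-c3ccccc3)o2)CC1` gives 18700 nM
compound 2 `O=C(CCSc1nc2c(c(=O)[nH]1)CCCC2)N[C@H]1CC[C@H](c2nnc(-c3ccccc3)o2)CC1` gives 3600 nM

Within the data shown here, in an ADME assay on the whole organism (strain CD-1) for pharmacokinetics, with Mus musculus as the target, at a dose of 30 mg/kg by the oral route (on this read-out higher numbers stand for higher exposure at the dose given and lower numbers for lower exposure), compound 1 at 18700 nM holds the higher of the two numbers so far. Compound 3 `N#Cc1ccc(O[C@H]2CC[C@H](NC(=O)CCSc3nc4ccccc4c(=O)[nH]3)CC2)cc1Cl` has not yet been measured. It keeps the core of compound 1 and differs in one place: 3-chloro-4-cyanophenoxy in place of 5-phenyl-1,3,4-oxadiazol-2-yl on a saturated ring carbon or in short, 3-chloro-4-cyanophenoxy in place of 5-phenyl-1,3,4-oxadiazol-2-yl on a saturated ring carbon.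

Among the measured compounds shown here, only one measured step exists, a 5.2-fold lower number from compound 1 to compound 2 (0.72 log units; beyond the scatter) and it lies elsewhere in the molecule, on a sulfur. It therefore says nothing direct about this exchange. For the measured compounds named here, it shows only that a single exchange in this small set can move this assay beyond the usual scatter. Compound 1 at 18700 nM is already the top number, so a drop looks likelier than a rise, of roughly the size of that one step. The expected change is a 2.7-fold lower number from compound 1 to compound 3 (0.43 log units; beyond the scatter) and this remains an uncertain estimate. For compound 3 the estimated value is 7000 nM with an expected range from 1500 nM to 30000 nM as a rough expectation.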

Compound 3, maximal plasma concentration: 15100 nM
Estimate against measurement, compound 3: 2.2-fold (0.33 log units) below; measured number inside the range.
By their numbers in this assay, from the lowest: compound 2; then compounds 3 and 1 (each within the scatter of the next).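

In this assay, the one exchange shown at the saturated ring carbon, 3-chloro-4-cyanophenoxy in place of 5-phenyl-1,3,4-oxadiazol-2-yl, gives a 1.2-fold lower number from compound 1 to compound 3 (0.09 log units; within the scatter) and so leaves the two compounds indistinguishable on this read-out. This position can therefore carry either of these two differently built groups, one with a five-membered aromatic ring joined to a benzene-type ring and the other with a single carbon-only aromatic ring bearing chlorine and a nitrile, without a measurable loss of exposure, unlike the exchange on the sulfur, which gives a 5.2-fold lower number from compound 1 to compound 2 (0.72 log units; beyond the scatter). Nothing measured here explains why the exposure holds at this position.

From the compounds shown here alone, both groups carry a six-membered aromatic ring of carbon only, so it remains open whether exposure would hold with a group lacking such a ring, such as a simple amine or a carboxylic acid, on that saturated ring carbon. Going by these compounds, it is also open whether 3-chloro-4-cyanophenoxy would behave the same way on the core of compound 2, whose exposure sits lower.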